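A few compounds are considered here, and "the series" means these few. Any claim that something is new, unique, unknown or untested is made for them only; others in the source may bear on it.

Series notes. Compound 1 `Cc1nc2ccccc2n1CC(=O)N/N=C/c1c(O)ccc2ccccc12` in a physicochemical assay for solubility, read by fluorescence and spectrophotometry (on this read-out higher numbers stand for higher solubility and lower numbers for lower solubility), gives 20000 nM. Compound 2 `Cc1nc2cc(Cl)ccc2n1CCC(=O)N/N=C/c1c(O)ccc2ccccc12` in this assay gives 210000 nM, the higher of the two numbers. The gap between compound 2 and compound 1 lies well beyond the usual scatter. The two compounds differ in more than one place, so no single step can be read from them. Compound 3 `Cc1nc2cc(Cl)c(Cl)cc2n1CCC(=O)N/N=C/c1c(O)ccc2ccccc12` is the next member and has not yet been measured in this assay. It differs from compound 2 by chloro in place of hydrogen on an aromatic carbon. Among the measured compounds shown here, no measured pair carries this change, so its effect cannot be read from the data at hand. The expected step in this assay is a 2.6-fold lower number from compound 2 to compound 3 (0.42 log units; beyond the scatter), a modest drop, somewhat beyond the scatter but with wide uncertainty on either side. For compound 3 the estimate in this assay is 80000 nM, with a range from 25000 nM to 250000 nM.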

Compound 3, solubility: 90000 nM
For compound 3 the middle estimate is 1.1-fold (0.05 log units) below the measured one; low and high end bracket the measured number.
By their numbers in this assay, from the lowest: compound 1; then compound 3; then compound 2.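

In this assay the series now has its first step that can be read at a single place: chloro in place of hydrogen on an aromatic carbon gives a 2.3-fold lower number from compound 2 to compound 3 (0.37 log units; beyond the scatter) as a modest change beyond the scatter. This reading belongs to a position ortho to a chloro group, meta to a fused ring and para to a fused ring, so it describes adding a second chloro to a ring that already carries one, not adding a first. Nothing at hand bears on the reason for this drop.

As far as these compounds go, whether the step holds without the ortho chloro group, or with methoxy or an amine entering in place of chloro, stays open. From the compounds shown here alone, the difference between compound 1 and compound 2 spans more than one place and cannot be read as a step, so the share of the first chloro remains unknown.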